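Shifting the Methoxyphenyl Group While Staying at the Limit

A few compounds are considered here, and "the series" means these few. Any claim that something is new, unique, unknown or untested is made for them only; others in the source may bear on it.

Of the compounds shown here, three have so far been tested in a functional assay on BGC-823 cells (Homo sapiens) for cytotoxicity, read by MTT assay; on this read-out lower numbers stand for stronger inhibition and higher numbers for weaker inhibition. Compound 1, `COc1cccc(/C=C/C(=O)c2sc(Nc3ccc(Cl)cc3)nc2C)c1`, was recorded as > 25000 nM, a limit of the assay rather than a number. Compound 2, `COc1cccc(/C=C/C(=O)c2sc(Nc3ccccc3C)nc2C)c1`, was likewise recorded only at a limit, > 25000 nM. Compound 3, `COc1ccc(/C=C/C(=O)c2sc(Nc3ccc(Cl)c(Cl)c3)nc2C)cc1`, also gave only a limit, > 25000 nM. Compound 3 therefore stands at the ceiling of this assay, as do the other two values; all three sit at the limit of > 25000 nM in this assay, at which 3 of the 3 values shown sit. Going by the values given here, the single one-point step within the measured set, a step that the two limits leave unreadable from compound 1 to compound 2, carries no readable size; both of its ends are limits.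

Compound 4, `COc1cccc(/C=C/C(=O)c2sc(Nc3ccc(Cl)c(Cl)c3)nc2C)c1`, is now to be measured in this assay. It differs from compound 3 in one place: 3-methoxyphenyl in place of 4-methoxyphenyl on a double-bonded chain carbon bound to a double-bonded chain carbon. Among the compounds with values here, no measured step bears directly on this exchange. What can be said is that compounds 1 and 2 already carry the 3-methoxyphenyl group, and both were recorded only as limits. Within the data shown here, nothing among the measured values points to a gain in cytotoxicity from this rearrangement. Compound 4 is therefore expected to remain at the limit as well, with the expected step that the limit leaves unreadable from compound 3 to compound 4 meaning no readable change. The estimate for compound 4 is 50000 nM, within a range from 25000 nM to 200000 nM.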

Compound 4, half-maximal inhibitory concentration: 8350 nM
Compound 4: the middle estimate sits 6.0-fold (0.78 log units) above what was measured, outside the stated range (below it).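

The exchange of 4-methoxyphenyl for 3-methoxyphenyl on a double-bonded chain carbon bound to a double-bonded chain carbon gives an at least 2.9-fold lower number from compound 3 to compound 4 (0.47 log units; beyond the scatter), the first readable effect at this position in this assay. With the 3-methoxyphenyl group held fixed, the aniline side also turns out to matter: 3,4-dichlorophenyl in place of 2-methylphenyl on a nitrogen on an aromatic ring gives an at least 2.9-fold lower number from compound 2 to compound 4 (0.47 log units; beyond the scatter), and chloro in place of hydrogen on an aromatic carbon gives an at least 2.9-fold lower number from compound 1 to compound 4 (0.47 log units; beyond the scatter). Compound 3 with the 3,4-dichlorophenyl group and compounds 1 and 2 with the 3-methoxyphenyl group all stay at a limit of the assay, so among these compounds only the two groups together leave it: the limit of > 25000 nM in this assay, at which 3 of the 4 values shown sit.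

From the compounds shown here alone, the true size of each of these steps remains open, since each starts from a limit, and the step between compound 1 and compound 2 cannot be read at all. Also open, going by these compounds, is whether this gain would survive another group on that phenyl ring, such as a carboxylic acid or a dimethylamino group in place of the methoxy.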